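A few compounds are considered here, and "the series" means these few. Any claim that something is new, unique, unknown or untested is made for them only; others in the source may bear on it.

Series notes. In an assay on isolated protein for inhibition of Rho-associated protein kinase 2 (Homo sapiens), read by radiometric assay (a lower number here means a stronger inhibitor, a higher number a weaker inhibitor), compound 1 `NCc1ccc(C(=O)Nc2ccncc2F)cc1-c1cccc(C(=O)Oc2ccccc2)c1` gives 6.2 nM, compound 2 `NCc1ccc(C(=O)Nc2ccncc2F)cc1-c1cccc(C(=O)OCCO)c1` gives 1.4 nM and compound 3 `CC(N)c1ccc(C(=O)Nc2ccncc2)cc1-c1ccc(F)cc1` gives 1.2 nM. Compound 2 stands second highest of these three numbers; its nearest neighbour is compound 3, within the scatter, and its furthest is compound 1, beyond it. Among the measured compounds shown here, the only single-site step measured so far is a 4.4-fold lower number from compound 1 to compound 2 (0.65 log units; beyond the scatter), a modest change made on an oxygen next to a carbonyl group. Compound 4 `COC(=O)c1cccc(-c2cc(C(=O)Nc3ccncc3F)ccc2CN)c1` is not yet measured; it differs from compound 2 by hydrogen in place of hydroxymethyl on a saturated chain carbon bound to an oxygen next to a carbonyl group, read one bond further out as 2-hydroxyethyl to methyl, or (2-hydroxyethoxy)carbonyl to methoxycarbonyl. For the measured compounds named here, only that measured step bears on this change, and it shows that the group on this ester oxygen shifts the number by a modest amount. A small step upward in this assay is therefore expected, at or just beyond the scatter, given that compound 2 sits at 1.4 nM. Compound 4 is estimated at 2.5 nM, with a range of 1 nM to 6 nM, meaning an expected step of a 1.8-fold higher number from compound 2 to compound 4 (0.25 log units; within the scatter).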

Compound 4, half-maximal inhibitory concentration: 7.8 nM
Estimate against measurement, compound 4: 3.1-fold (0.49 log units) below; measured number outside the range, above it.
By their numbers in this assay, from the lowest: compounds 3 and 2 (each within the scatter of the next); then compounds 1 and 4 (each within the scatter of the next).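

In this assay, the 2-hydroxyethyl to methyl change gives a 5.6-fold higher number from compound 2 to compound 4 (0.75 log units; beyond the scatter), so the hydroxymethyl lost here marks a difference that the phenyl comparison alone could not isolate. Replacing phenyl with methyl gives a 1.3-fold higher number from compound 1 to compound 4 (0.10 log units; within the scatter), leaving those two esters unseparated, and compound 2 is the only one of the three esters that stands apart from the other two. Nothing shown gives a reason for this difference.

From the compounds shown here alone, it remains open whether the result follows the terminal hydroxyl or the length of the chain, a question that an ethyl ester and a 2-methoxyethyl ester would address. A 2-aminoethyl ester, a 3-hydroxypropyl ester or the free carboxylic acid would show how far this position tolerates other groups.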